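Swapping the Amine on the Acrylamide Side Chain

A few compounds are considered here, and "the series" means these few. Any claim that something is new, unique, unknown or untested is made for them only; others in the source may bear on it.

Compound 1 `CCN(CC)C/C=C/C(=O)Nc1cc2c(N3CCc4ccccc43)ncnc2cc1OC` and compound 2 `COc1cc2ncnc(N3CCc4ccccc43)c2cc1NC(=O)/C=C/CN1CCCC1` share a core and differ only in the amine at the end of the side chain. In a functional assay on MCF7 cells (Homo sapiens) for antiproliferative activity, read by MTT assay, with a stated time of 72 h (a higher number here means a weaker inhibitor, a lower number a stronger inhibitor), compound 1 gives 1990 nM, and compound 2 gives 1510 nM. The change pyrrolidin-1-yl in place of diethylamino on a saturated chain carbon bound to a double-bonded chain carbon made a 1.3-fold lower number from compound 1 to compound 2 (0.12 log units; within the scatter).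

Compound 3 `CCN(CC)C/C=C/C(=O)Nc1cc2c(N3CCCc4ccccc43)ncnc2cc1O[C@@H]1CCOC1` has a different core; how the two cores differ is not broken down here. In this assay compound 3 gives 3870 nM.

Compound 4 `O=C(/C=C/CN1CCCC1)Nc1cc2c(N3CCCc4ccccc43)ncnc2cc1O[C@@H]1CCOC1` is obtained from compound 3 by the same change, (pyrrolidin-1-yl in place of diethylamino on a saturated chain carbon bound to a double-bonded chain carbon). Because a 1.3-fold lower number from compound 1 to compound 2 (0.12 log units; within the scatter) the expected step is a 1.3-fold lower number from compound 3 to compound 4 (0.11 log units; within the scatter), small and within the usual scatter. Compound 4 is therefore estimated to give 3000 nM, likely between 1500 nM and 6000 nM.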

Compound 4, half-maximal inhibitory concentration: 4250 nM
Estimate against measurement, compound 4: 1.4-fold (0.15 log units) below, and the stated range covers the measured number.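

On the core of compound 3, pyrrolidin-1-yl in place of diethylamino gave a 1.1-fold higher number from compound 3 to compound 4 (0.04 log units; within the scatter), so in this assay the change again stayed inside the usual scatter. Set side by side, the two steps agree: the same change on two cores in this assay, a 1.3-fold lower number (0.12 log units; within the scatter) from compound 1 to compound 2 and a 1.1-fold higher number (0.04 log units; within the scatter) from compound 3 to compound 4, 1.4-fold (0.16 log units) apart, within the scatter of two such steps. This shows that the change carried over from one core to the other as a step too small to read, but it gives the change no clear direction and says nothing about other cores or other assays.

The compounds shown leave open whether another amine at this place, such as morpholin-4-yl or piperidin-1-yl, would move the number beyond the scatter. On these data alone, whether a longer chain carrying the amine would do so also remains open.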